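Cytotoxicity notes: aryl amide swap on the shared core

This account rests on a few compounds, and the source may have more. Where it says the series, first, only, none or still open, it means among the compounds named here.

Compound 1 `CCN(CC)c1cc2[nH]c(C3CCCCC3)nc2cc1NC(=O)c1ccc(F)cc1` gives > 100 ug/mL in an ADME assay on Vero cells (Chlorocebus sabaeus) for cytotoxicity, read by resazurin assay, with a stated time of 3 days; on this read-out higher numbers stand for weaker inhibition and lower numbers for stronger inhibition; this is a limit of the assay, not a number.
Compound 2 `CCCOCC(=O)Nc1cc2nc(C3CCCCC3)[nH]c2cc1N(C)C` gives < 50 ug/mL in this assay; this too is a limit.

Compound 1 sits at the limit of > 100 ug/mL in this assay, at which 1 of the 2 values shown sits. Compound 2 sits at the limit of < 50 ug/mL in this assay, at which 1 of the 2 values shown sits. No step between measured compounds is available, as the two differ in more than one place, and the two limits do not overlap, so only this much is shown by the pair.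

Compound 3 `CCN(CC)c1cc2[nH]c(C3CCCCC3)nc2cc1NC(=O)c1cccc(Br)c1` is not yet measured. It differs from compound 1 in one place: 3-bromophenyl in place of 4-fluorophenyl on a carbonyl carbon. The change keeps the amide and the shared core intact.

Among the measured compounds shown here, with no measured step on this change, the step from compound 1 to compound 3 in this assay is expected to be none beyond the scatter, a number no higher from compound 1 to compound 3 (the limit leaves the size open), and compound 3 is estimated at 100 ug/mL, within 40 ug/mL to 200 ug/mL, most likely reported again as a limit.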

Compound 3, half-maximal inhibitory concentration: > 100 ug/mL
Compound 3 gave a limit, no number (the forecaster's own chance of this, stated with the estimate: 60%); the middle value lies on the limit itself.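

In this assay compound 3 gives > 100 ug/mL, a limit and not a number. Among the compounds shown here, compound 1 also stands at a limit, and no step between compound 1 and compound 3 can be read. The compounds shown leave open whether 3-bromophenyl in place of 4-fluorophenyl on a carbonyl carbon changes this read-out at all.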